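Ethynyl Added at the Amine Chain Carbon

The source may report more compounds than this note shows. Statements on the series, on what has been measured and on what is new or still open speak of the compounds shown alone.

Going by the values given here, compound 2 `Cc1nc(O)c2cc(CN(C)c3ccc(C(=O)N[C@@H](CCC(=O)O)C(=O)N(C)[C@@H](CCC(=O)O)C(=O)O)c(F)c3)ccc2n1` gives 23 nM in an assay on L1210 cells for inhibition of Thymidylate synthase (Mus musculus) (a higher number here means a weaker inhibitor, a lower number a stronger inhibitor), the higher of the two numbers measured so far. Its nearest neighbour, compound 1 `C#CCN(Cc1ccc2nc(C)nc(O)c2c1)c1ccc(C(=O)N[C@@H](CCC(=O)O)C(=O)N(C)[C@@H](CCC(=O)O)C(=O)O)cc1`, gives 11 nM in this assay, and the gap between the two lies beyond the usual scatter. Compound 3 `C#CCN(Cc1ccc2nc(C)nc(O)c2c1)c1ccc(C(=O)N[C@@H](CCC(=O)O)C(=O)N(C)[C@@H](CCC(=O)O)C(=O)O)c(F)c1` has not yet been measured. It differs from compound 2 by ethynyl in place of hydrogen on a saturated chain carbon bound to a nitrogen on an aromatic ring. Compound 1 also carries the propargyl group but lacks the fluorine shared by compounds 2 and 3, so the two measured values do not isolate this single change. Because compound 1 with its propargyl group gives 11 nM, compound 3 is expected to settle near that level. The step from compound 2 to compound 3 is therefore expected to be a 2.3-fold lower number from compound 2 to compound 3 (0.36 log units; beyond the scatter), toward a lower number. The inhibition constant of compound 3 is estimated at 10 nM, within a range from 4 nM to 25 nM.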

Compound 3, inhibition constant: 4 nM
Estimate against measurement, compound 3: 2.5-fold (0.40 log units) above; the range from low to high includes it.
By their numbers in this assay, from the lowest: compound 3; then compound 1; then compound 2.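

In this assay, the change from methyl to propargyl on the saturated chain carbon bound to a nitrogen on an aromatic ring gives a 5.8-fold lower number from compound 2 to compound 3 (0.76 log units; beyond the scatter), a single-place step that the two earlier compounds, which differ in more than one place, could not isolate. Fluoro in place of hydrogen on an aromatic carbon, with the propargyl group present, gives a 2.8-fold lower number from compound 1 to compound 3 (0.44 log units; beyond the scatter), so each single change lowers the number and compound 3, which carries both, stands lowest of the three. No measurement shown gives a reason for either step.

On these data alone, whether the fluoro step would be the same size with methyl in place of propargyl remains open. So does how an ethyl, an allyl or a longer chain at this position, or chloro in place of fluoro, would compare.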